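The source may hold more compounds than are shown below. What is called first, only, known or untested is meant among the compounds shown, and "the series" means these compounds.

Working notes on the series, read in a physicochemical assay for solubility, at pH 6.6; a lower number here means a less soluble compound, a higher number a more soluble compound. Within the data shown here, compound 1 (`CC(c1ccccc1)c1nc2c(C(F)(F)F)cccc2c(C(=O)O)c1O`) gives 1550 ug/mL, the higher of the two numbers so far, and compound 2 (`CC(C)C(c1ccccc1)c1nc2c(C(F)(F)F)cccc2c(C(=O)O)c1O`) gives 30 ug/mL. Compound 3 (`CC(Cc1ccccc1)c1nc2c(C(F)(F)F)cccc2c(C(=O)O)c1O`) has not been measured. Its difference from compound 1 is benzyl in place of phenyl on a saturated chain carbon bound to an aromatic carbon and a saturated chain carbon.

Among the measured compounds shown here, only one measured step bears on this change. It is a 52-fold lower number from compound 1 to compound 2 (1.71 log units; beyond the scatter), a large step beyond the scatter, with isopropyl in place of methyl on a saturated chain carbon bound to two aromatic carbons. For the measured compounds named here, that step replaces methyl, whereas compound 3 replaces phenyl, so it is only a loose guide, and no measured pair covers benzyl for phenyl. A step to a lower number is expected, smaller than the measured one but probably still beyond the scatter. The expected size is a 5.2-fold lower number from compound 1 to compound 3 (0.71 log units; beyond the scatter). For compound 3 the estimated value is 300 ug/mL, with an expected range of 70 ug/mL to 1200 ug/mL.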

Compound 3, solubility: 1550 ug/mL
For compound 3 the middle estimate is 5.2-fold (0.71 log units) below the measured one, and the stated range ends below it.
By their numbers in this assay, from the lowest: compound 2; then compounds 1 and 3 (each within the scatter of the next).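

In this assay the change of phenyl to benzyl on a saturated chain carbon bound to an aromatic carbon and a saturated chain carbon gives no change at the digits printed from compound 1 to compound 3 (within the scatter) and so stays within the scatter. Among these compounds, this position therefore accepts benzyl in place of phenyl with no readable shift in solubility, which the earlier pair could not show, as its only step was a 52-fold lower number from compound 1 to compound 2 (1.71 log units; beyond the scatter) for isopropyl in place of methyl. A larger group on this part of compound 1 thus does not by itself bring a step beyond the scatter, with compound 2 the one case here that has such a step, and nothing available explains why the two changes read so differently.

Still open, on these data alone, is whether a longer chain such as phenethyl, or an amine or a carboxylic acid on the benzyl ring, would also leave the number within the scatter of compound 1. Also open, as far as these compounds go, is how isopropyl in place of methyl would read with benzyl present, since a single pair of changes cannot separate the contribution of each group.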